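A few compounds are considered here, and "the series" means these few. Any claim that something is new, unique, unknown or untested is made for them only; others in the source may bear on it.

Compound 1 `CCN1CCN(c2cc(C)c3cc(NC(=O)c4ccccc4Br)ccc3n2)CC1`: 27500 nM
Compound 2 `CCN1CCN(c2cc(C)c3cc(NC(=O)c4ccc5ccccc5n4)ccc3n2)CC1`: 7060 nM

In a functional assay on MCF7 cells (Homo sapiens) for antiproliferative activity, read by MTT assay, with a stated time of 72 h (a lower number here means a stronger inhibitor, a higher number a weaker inhibitor), compound 2 gives 7060 nM, the lower of the two numbers and so the stronger result. Compound 3 `CCN1CCN(c2cc(C)c3cc(NC(=O)c4cccc(Br)c4)ccc3n2)CC1` has not yet been measured. It differs from compound 2 as follows: 3-bromophenyl in place of quinolin-2-yl on a carbonyl carbon. In words, it has 3-bromophenyl in place of quinolin-2-yl on a carbonyl carbon.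

For the measured compounds named here, only one measured step bears on this change: a 3.9-fold lower number from compound 1 to compound 2 (0.59 log units; beyond the scatter). That modest step put quinolin-2-yl in place of 2-bromophenyl. Going by the values given here, compound 3 goes back to a bromophenyl, but 3-bromophenyl is not 2-bromophenyl, and no measured compound shows what that difference does. A higher number is therefore expected in this assay, by a similar or somewhat smaller step.

The expected change is a 2.1-fold higher number from compound 2 to compound 3 (0.33 log units; beyond the scatter). Compound 3 is estimated at 15000 nM, with an expected range of 6000 nM to 40000 nM.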

Compound 3, half-maximal inhibitory concentration: 11600 nM
Compound 3: the middle estimate sits 1.3-fold (0.11 log units) above what was measured, and the stated range covers the measured number.
By their numbers in this assay, from the lowest: compounds 2 and 3 (each within the scatter of the next); then compound 1.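

In this assay, the change reads as a 1.6-fold higher number from compound 2 to compound 3 (0.22 log units; within the scatter), so this assay does not separate 3-bromophenyl from quinolin-2-yl on this carbonyl carbon, and the larger ring system is not needed to reach this level of activity. The bromophenyl groups, by contrast, can be told apart, with a 2.4-fold lower number from compound 1 to compound 3 (0.37 log units; beyond the scatter) showing that where the bromine sits on the ring changes the result, even though the two groups share the same atoms. No measurement shown here explains either result.

From the compounds shown here alone, what remains open is whether the bromine itself contributes, since a plain phenyl group would be needed to show this. It is also unclear whether a chlorine or a methoxy group in the bromine's place would give a similar number.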